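Thiophene Carboxamides: Swapping the Ring Nitrogen Substituent

A few compounds are considered here, and "the series" means these few. Any claim that something is new, unique, unknown or untested is made for them only; others in the source may bear on it.

Measured so far:
compound 1 `NC(=O)c1c(NC(=O)c2ccccc2Cl)sc2c1CCN(Cc1ccccc1)C2`: 12000 nM
compound 2 `NC(=O)c1c(NC(=O)c2ccccc2Cl)sc2c1CCN(C(=O)Nc1ccccc1Cl)C2`: 12500 nM
compound 3 `CSc1ccccc1NC(=S)N1CCc2c(sc(NC(=O)c3ccccc3Cl)c2C(N)=O)C1`: 14600 nM

All three were tested in a functional assay on HL-60 cells (Homo sapiens) for antiproliferative activity, with a stated time of 24 h; a higher number here means a weaker inhibitor, a lower number a stronger inhibitor. Compound 1 has the lowest of the three numbers, but its steps to compound 2 a 1.0-fold higher number from compound 1 to compound 2 (0.02 log units; within the scatter) and to compound 3 a 1.2-fold higher number from compound 1 to compound 3 (0.09 log units; within the scatter) both lie within the scatter, as does a 1.2-fold higher number from compound 2 to compound 3 (0.07 log units; within the scatter). So far, changing the group on the amine nitrogen in the ring has not moved the number.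

Compound 4 `NC(=O)c1c(NC(=O)c2ccccc2Cl)sc2c1CCN(C(=S)Nc1c(Cl)cccc1Cl)C2` carries the same change in kind: a group of 11 heavy atoms (7 carbon, 1 nitrogen, 1 sulfur, 2 chlorine; one six-membered aromatic ring of carbon only) in place of a group of 7 heavy atoms (7 carbon; one six-membered aromatic ring of carbon only), on an amine nitrogen in a ring. It enters a group of 11 heavy atoms with one hydrogen-bond donor and one acceptor in place of benzyl, much as compound 2 and compound 3 did. Because the steps of a 1.0-fold higher number from compound 1 to compound 2 (0.02 log units; within the scatter) and a 1.2-fold higher number from compound 1 to compound 3 (0.09 log units; within the scatter) stayed within the scatter, the expected step of a 1.0-fold higher number from compound 1 to compound 4 (0.02 log units; within the scatter) is none beyond the scatter. Compound 4 is therefore estimated at 12500 nM, within 6000 nM to 26000 nM.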

Compound 4, half-maximal inhibitory concentration: 3950 nM
Estimate against measurement, compound 4: 3.2-fold (0.50 log units) above; measured number outside the range, below it.
By their numbers in this assay, from the lowest: compound 4; then compounds 1, 2 and 3 (each within the scatter of the next).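

In this assay, the group on the amine nitrogen in the ring can shift the number after all, with a 3.0-fold lower number from compound 1 to compound 4 (0.48 log units; beyond the scatter) and a 3.2-fold lower number from compound 2 to compound 4 (0.50 log units; beyond the scatter) as modest steps. Compound 3 and compound 4 differ only in 2,6-dichlorophenyl in place of 2-(methylsulfanyl)phenyl on an amide-type nitrogen, and a 3.7-fold lower number from compound 3 to compound 4 (0.57 log units; beyond the scatter) shows that this aromatic group matters, not only the link to the core. No available evidence bears on this result. The step between compound 2 and compound 4 changes both the link and the chlorine count, so neither change can be credited alone. From the compounds shown here alone, whether 2,6-dimethylphenyl on the same link would keep the lower number remains open.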